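The source may hold more compounds than are shown below. What is called first, only, known or untested is meant among the compounds shown, and "the series" means these compounds.

Working notes on the series.

Compound 1 `CSC[C@H](NC(C)=O)C(=O)CCl` gives 80800 nM in a functional assay on MOLT-3 cells (Homo sapiens); a lower number here means a stronger inhibitor, a higher number a weaker inhibitor. Compound 2 `CCCCSC[C@H](NC(C)=O)C(=O)CCl` gives 5600 nM in this assay, and compound 3 `CCCCCSC[C@H](NC(C)=O)C(=O)CCl` gives 5400 nM in this assay. The only variable so far is the length of the chain on the sulfur: a 14-fold lower number from compound 1 to compound 2 (1.16 log units; beyond the scatter) and a 15-fold lower number from compound 1 to compound 3 (1.18 log units; beyond the scatter), whereas a 1.0-fold lower number from compound 2 to compound 3 (0.02 log units; within the scatter). On the numbers shown compound 3 stands at the lowest value of the three, but its difference from compound 2 lies within the scatter, so the two cannot be separated; only the gap to compound 1 is beyond it.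

Compound 4 `CCCCCCSC[C@H](NC(C)=O)C(=O)CCl` has not yet been measured. It differs from compound 3 by methyl in place of hydrogen on a saturated chain carbon, five bonds along the chain from a sulfur. The step that bears directly on this is the lengthening from compound 2 to compound 3, a 1.0-fold lower number from compound 2 to compound 3 (0.02 log units; within the scatter), which did not move the number beyond the scatter. The large steps of a 14-fold lower number from compound 1 to compound 2 (1.16 log units; beyond the scatter) and a 15-fold lower number from compound 1 to compound 3 (1.18 log units; beyond the scatter) start from the shortest chain and do not speak to a further extension of an already long chain. The expectation for compound 4 in this assay is therefore a step of a 1.1-fold lower number from compound 3 to compound 4 (0.03 log units; within the scatter) that stays within the scatter. Compound 4 is estimated at 5000 nM, with a range from 2500 nM to 11000 nM.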

Compound 4, half-maximal inhibitory concentration: 700 nM
For compound 4 the middle estimate is 7.1-fold (0.85 log units) above the measured one; measured number outside the range, below it.
By their numbers in this assay, from the lowest: compound 4; then compounds 3 and 2 (each within the scatter of the next); then compound 1.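

In this assay the chain on the sulfur still responds at this length: methyl in place of hydrogen on a saturated chain carbon, five bonds along the chain from a sulfur, gives a 7.7-fold lower number from compound 3 to compound 4 (0.89 log units; beyond the scatter) and so lies beyond the scatter, whereas the preceding extension, a 1.0-fold lower number from compound 2 to compound 3 (0.02 log units; within the scatter), did not. The response to chain length across these four compounds is therefore not smooth, with a large drop from the shortest chain, no separable change at the next extension, and then a further drop, as the ethyl change also shows in an 8.0-fold lower number from compound 2 to compound 4 (0.90 log units; beyond the scatter) and the pentyl change in a 120-fold lower number from compound 1 to compound 4 (2.06 log units; beyond the scatter). With all of its steps beyond the scatter, compound 4 is the strongest inhibitor of the four, and nothing at hand offers an explanation for the sudden change at this position.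

Going by these compounds, whether a longer chain would lower the number further, hold it or raise it remains open. Also open, on these data alone, is how a branched chain, a phenyl ring, an amine or a carboxylic acid at the end of the chain would compare with the plain hexyl chain of compound 4.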